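The source may report more compounds than this note shows. Statements on the series, on what has been measured and on what is new or still open speak of the compounds shown alone.

Measured so far:
- compound 1, `FC(F)(F)c1ccc(C2CC(c3ccccc3)=NN2c2ccc(-c3ccccc3)nn2)cc1`, gives 10000 nM
- compound 2, `COc1ccc(C2CC(c3ccccc3)=NN2c2ccc(-c3ccccc3)nn2)cc1`, gives > 100000 nM
- compound 3, `FC(F)(F)c1ccc(C2CC(c3ccc(Cl)cc3)=NN2c2ccc(-c3ccccc3)nn2)cc1`, gives 8330 nM

All three were tested in a functional assay on HepG2 cells (Homo sapiens) for antiproliferative activity, read by MTT assay, with a stated time of 24 h; on this read-out higher numbers stand for weaker inhibition and lower numbers for stronger inhibition. For compound 2 the value is a limit of the assay and not a number, so compound 2 is known only to sit at the limit of > 100000 nM in this assay, at which 1 of the 3 values shown sits.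

Compound 1 and compound 2 differ in one place: methoxy in place of trifluoromethyl on an aromatic carbon. This change gave an at least 10-fold higher number from compound 1 to compound 2 (1.00 log units; beyond the scatter), and the step is an at-least figure due to the limit of > 100000 nM in this assay, at which 1 of the 3 values shown sits.

Compound 3 differs from compound 1 in another place: chloro in place of hydrogen on an aromatic carbon. That change gave a 1.2-fold lower number from compound 1 to compound 3 (0.08 log units; within the scatter), so compound 1 and compound 3 cannot be told apart on this read-out.

Compound 4, `COc1ccc(C2CC(c3ccc(Cl)cc3)=NN2c2ccc(-c3ccccc3)nn2)cc1`, has not yet been tested. It differs from compound 3 by methoxy in place of trifluoromethyl on an aromatic carbon. The place is described in the same words as for the change from compound 1 to compound 2, so this is the same change, now made on the core of compound 3.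

Because compound 1 gave 10000 nM and compound 2 gave > 100000 nM, the same change on compound 3 is expected to give a step of about a 12-fold higher number from compound 3 to compound 4 (1.08 log units; beyond the scatter). On that basis compound 4 is expected to come out near 100000 nM, most likely reported only as a limit, with a range of about 30000 nM to 300000 nM.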

Compound 4, half-maximal inhibitory concentration: > 100000 nM
Compound 4: only a limit was reported; the forecaster's own chance of this, stated with the estimate: 70%; the middle value sits exactly at the limit.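

In this assay, putting methoxy in place of trifluoromethyl on the core of compound 3 gave an at least 12-fold higher number from compound 3 to compound 4 (1.07 log units; beyond the scatter), which means weaker inhibition, and set beside the earlier case the change reads: the same change on two cores in this assay, an at least 10-fold higher number (1.00 log units; beyond the scatter) from compound 1 to compound 2 and an at least 12-fold higher number (1.07 log units; beyond the scatter) from compound 3 to compound 4; the limit leaves it open whether they differ. Compound 2 and compound 4 are each reported only as a limit of the assay and not as a number: the limit of > 100000 nM in this assay, at which 2 of the 4 values shown sit. So the direction of the change carries over from one core to the other in these two pairs, but the true size of the step on either core is not shown, and the step from compound 2 to compound 4, chloro in place of hydrogen, cannot be read.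

The compounds shown leave open what other groups in the place of trifluoromethyl would do on these cores, for example a nitrile, an amine or a carboxylic acid, and whether any of them would keep or improve on the inhibition seen with the trifluoromethyl compounds. On these data alone, it also remains open whether the same change would behave alike on a third core, such as one carrying bromo or methyl in place of the chloro of compound 3.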